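A few compounds are considered here, and "the series" means these few. Any claim that something is new, unique, unknown or untested is made for them only; others in the source may bear on it.

Measured so far in a functional assay on HeLa cells (Homo sapiens) for cytotoxicity; on this read-out lower numbers stand for stronger inhibition and higher numbers for weaker inhibition:
- compound 1 `CCOC1=CC(=O)c2ccccc2C1=O`: 23800 nM
- compound 2 `O=C(Oc1ccc2c(c1)C(=O)C=CC2=O)c1ccccc1`: 19200 nM

Compound 1 has the highest of the two numbers. Its nearest neighbour is compound 2, and the gap between the two values lies within the scatter, so nothing can be read into their order; both are weak inhibitors in this assay.

The next step takes compound 1 to compound 3 `C/C=C/C(=O)OC1=CC(=O)c2ccccc2C1=O`. The change is (prop-1-en-1-yl)carbonyl in place of ethyl on an oxygen on an unsaturated carbon. Going by the values given here, no step between two measured compounds is available here, so the size of the move has to be judged from the change alone. Among the compounds with values here, the shared core is kept, and the only other measured compound, compound 2, also carries a carbonyl-bearing oxygen substituent and sits in the same region of the scale, so a large move in either direction is not expected. A modest shift toward a lower number, of a size that would still sit near the edge of the scatter, seems the most likely outcome.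

Compound 3 is therefore expected to give about 15000 nM in this assay, with a plausible range from 5000 nM to 45000 nM. This estimate corresponds to an expected step of a 1.6-fold lower number from compound 1 to compound 3 (0.20 log units; within the scatter).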

Compound 3, half-maximal inhibitory concentration: 37900 nM
Compound 3: middle estimate off by 2.5-fold (0.40 log units), on the low side, and the stated range covers the measured number.
By their numbers in this assay, from the lowest: compounds 2, 1 and 3 (each within the scatter of the next).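

In this assay, going by these compounds alone, (prop-1-en-1-yl)carbonyl in place of ethyl on an oxygen on an unsaturated carbon gives a 1.6-fold higher number from compound 1 to compound 3 (0.20 log units; within the scatter) and provides the first directly readable step, one that stays within the scatter. The entering group has 5 heavy atoms against 2 for ethyl and brings 1 hydrogen-bond acceptor and 2 double bonds outside aromatic rings, yet this read-out shows no difference that can be separated from the scatter, so at this position and at this level of activity, the exchange of ethoxy for ((prop-1-en-1-yl)carbonyl)oxy leaves the result effectively unresolved. No supporting measurement accompanies this step, so nothing can be said about what lies behind the result.

Within the data shown here, with only this single exchange at the position, it remains open whether the double bond of the entering group matters, which a comparison with the saturated butanoyl group would address. On these data alone, it also remains open whether any substituent on this oxygen can shift the number beyond the scatter, for example a longer alkyl chain or a chain ending in an amine or a carboxylic acid.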